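Replacing a Chlorinated Benzyl Tail with a Nitro-Bearing One

The source may report more compounds than this note shows. Statements on the series, on what has been measured and on what is new or still open speak of the compounds shown alone.

Of the compounds shown here, two built on a shared core have been measured so far. Compound 1 `COc1cccc(OC)c1OCCNCCOc1ccccc1OCc1ccccc1` carries an unsubstituted benzyl ether, and in an assay on CHO cells for displacement of a labelled ligand from Alpha-1A adrenergic receptor (Homo sapiens) (a lower number here means a stronger inhibitor, a higher number a weaker inhibitor), compound 1 gives 0.468 nM. Compound 2 `COc1cccc(OC)c1OCCNCCOc1ccccc1OCc1cccc(Cl)c1` adds a chlorine to that benzyl ring, and in this assay compound 2 gives 0.251 nM. Among the compounds with values here, the one step connecting them, a 1.9-fold lower number from compound 1 to compound 2 (0.27 log units; within the scatter), is within the scatter, so compound 2 stands at one end of the two numbers without being separable from compound 1.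

Compound 3 `COc1cccc(OC)c1OCCNCCOc1ccccc1OCc1ccc([N+](=O)[O-])cc1` differs from compound 2 by 4-nitrophenyl in place of 3-chlorophenyl on a saturated chain carbon bound to an oxygen on an aromatic ring. Within the data shown here, no measured step covers this exchange: the only step in hand concerns adding a chlorine to a bare ring, not trading a chlorinated ring for a nitro-bearing one, and it was itself small. With nothing pointing to a large shift, the expectation in this assay is a step of modest size, most likely within the scatter, with a slight lean toward a higher number. Compound 3 is therefore expected to give about 0.4 nM, with a range from 0.15 nM to 1.2 nM. This estimate corresponds to an expected 1.6-fold higher number from compound 2 to compound 3 (0.20 log units; within the scatter).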

Compound 3, inhibition constant: 1.26 nM
Compound 3: middle estimate off by 3.2-fold (0.50 log units), on the low side, outside the stated range (above it).
By their numbers in this assay, from the lowest: compounds 2 and 1 (each within the scatter of the next); then compound 3.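

In this assay, within the data shown here, the exchange of 3-chlorophenyl for 4-nitrophenyl on a saturated chain carbon bound to an oxygen on an aromatic ring gives a 5.0-fold higher number from compound 2 to compound 3 (0.70 log units; beyond the scatter) and so provides the first step beyond the scatter. The comparison with the unsubstituted benzyl ring points the same way, since putting a nitro group on that bare ring gives a 2.7-fold higher number from compound 1 to compound 3 (0.43 log units; beyond the scatter) while chloro in place of hydrogen stayed within the scatter, so this part of the molecule does not accept every substituent equally in this assay. No measurement here bears on why the number rises.

The exchange changes both the substituent and its printed ring position, leaving open whether the higher number follows the nitro group itself or the place it occupies. Going by these compounds, it is also open how an amine or a carboxylic acid on this benzyl ring would compare, and whether such groups would stay within the scatter of compound 1 or move as far as the nitro group does.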